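The source may hold more compounds than are shown below. What is called first, only, known or untested is meant among the compounds shown, and "the series" means these compounds.

Of the compounds shown here, three have been measured in a functional assay on SK-OV-3 cells (Homo sapiens) for inhibition, read by sulforhodamine B assay, with a stated time of 48 h, tested at 100 uM; on this read-out higher numbers stand for a weaker effect at the one concentration tested and lower numbers for a stronger effect. Compound 1 `O=C(Nc1cccc(-n2cc(-c3ccncc3)c(-c3cc(O)cc(Cl)c3)n2)c1)Nc1ccc(Cl)c(Cl)c1` gives -22% in this assay. Compound 2 `COc1cc(Cl)cc(-c2nn(-c3cccc(NC(=O)Nc4ccc(Cl)c(C(F)(F)F)c4)c3)cc2-c2ccncc2)c1` gives -39% in this assay. Compound 3 `COc1cc(Cl)cc(-c2nn(-c3cccc(NC(=O)Nc4cc(C(F)(F)F)cc(C(F)(F)F)c4)c3)cc2-c2ccncc2)c1` gives -73% in this assay, the lowest of the three numbers; its nearest neighbour is compound 2, separated by a gap beyond the scatter, and the furthest is compound 1, separated by a larger gap, also beyond the scatter. Compound 4 `COc1cc(Cl)cc(-c2nn(-c3cccc(NC(=O)Nc4cccc(C(F)(F)F)c4)c3)cc2-c2ccncc2)c1` has not yet been measured. It differs from compound 3 by hydrogen in place of trifluoromethyl on an aromatic carbon. Among the compounds with values here, no step between measured compounds differing in one place is available, so the expectation rests on compound 3 alone and on the loss of one trifluoromethyl. The step from compound 3 to compound 4 is expected to be a number 28 percentage points higher from compound 3 to compound 4 (beyond the scatter), a move towards a weaker effect. Compound 4 is estimated at -45%, within a range from -75% to -10%.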

Compound 4, a percentage reported as activity, at one concentration (the size of the read-out at that concentration, not a potency): -3%
Compound 4: the middle estimate sits 42 percentage points below what was measured; measured number outside the range, above it.
By their numbers in this assay, from the lowest: compound 3; then compound 2; then compound 1; then compound 4.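

In this assay, hydrogen in place of trifluoromethyl gives a number 70 percentage points higher from compound 3 to compound 4 (beyond the scatter) and hydrogen in place of chloro gives a number 36 percentage points higher from compound 2 to compound 4 (beyond the scatter) on the same aromatic ring. Both steps end at compound 4, so on this ring a second group, whether trifluoromethyl or chloro, goes with a clearly stronger effect than hydrogen does. Nothing shown here explains the size of these steps. Still open, on these data alone, is whether a methyl, a nitrile or an amine on that carbon would keep the stronger effect. Also open, as far as these compounds go, is what hydrogen in place of the remaining trifluoromethyl would do.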